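Shortening the thioamide chain on a pyridazinone-type series

This account rests on a few compounds, and the source may have more. Where it says the series, first, only, none or still open, it means among the compounds named here.

Compound 2 `Cc1ccc(=O)n(CCCCC(=N)S)n1`: 29.5%
Compound 1 `N=C(S)CCCn1nc(-c2ccccc2)ccc1=O`: 75.6%

Going by the values given here, in a functional assay on the whole organism (stomach) for inhibition, with Rattus norvegicus as the target, at a dose of 100 mg/kg by the intraduodenal route (on this read-out higher numbers stand for more inhibition at the one dose given (going by the name of the read-out) and lower numbers for less inhibition), compound 2 gives 29.5%, the lower of the two numbers measured so far. Its nearest neighbour, compound 1 with 75.6%, stands well beyond the scatter above it; the two differ at more than one place, so their gap cannot be assigned to a single change.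

Compound 3 `Cc1ccc(=O)n(CCCC(=N)S)n1` departs from compound 2 by the change (a group of 3 heavy atoms (1 carbon, 1 nitrogen, 1 sulfur; no ring) in place of a group of 4 heavy atoms (2 carbon, 1 nitrogen, 1 sulfur; no ring), on a saturated chain carbon, three bonds along the chain from an aromatic nitrogen), that is, the chain to the thioamide becomes one carbon shorter, as in compound 1. Among the compounds with values here, since no single-change step between measured compounds exists here, the direction of this assay rests on weak ground. Compound 2 and compound 1 together suggest some gain may accompany the shorter chain, though the aryl group also differs between them. Compound 3 is therefore estimated at 42%, within 15% to 70%, an expected step of a number 12.5 percentage points higher from compound 2 to compound 3 (beyond the scatter).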

Compound 3, a percentage reported as inhibition, in the whole organism at one dose (the size of the read-out at that dose, not a potency): 36.3%
For compound 3 the middle estimate is 5.7 percentage points above the measured one; measured number inside the range.
By their numbers in this assay, from the lowest: compounds 2 and 3 (each within the scatter of the next); then compound 1.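

In this assay, taking one carbon off the chain to the thioamide, on a saturated chain carbon, gives a number 6.8 percentage points higher from compound 2 to compound 3 (within the scatter) and so leaves no resolved effect of chain length in the methyl series. Going by these compounds alone, the first single-change reading of the aromatic carbon comes from methyl in place of phenyl, which gives a number 39.3 percentage points lower from compound 1 to compound 3 (beyond the scatter) and is a large step at this shorter chain length. Thus, of the two single changes now readable, only the change on the aromatic carbon lies beyond the scatter, and nothing at hand accounts for either step.

Going by these compounds, whether phenyl on the aromatic carbon would hold its effect with the longer chain remains open. So does how an ethyl group, a pyridyl ring or an amine would read on that aromatic carbon, and whether a still shorter chain would read differently.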